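Bromo in place of methoxy in a small series

This account rests on a few compounds, and the source may have more. Where it says the series, first, only, none or still open, it means among the compounds named here.

Among the compounds with values here, in a functional assay on MCF7 cells (Homo sapiens) for antiproliferative activity, read by MTT assay, with a stated time of 72 h (on this read-out lower numbers stand for stronger inhibition and higher numbers for weaker inhibition), compound 2 `COc1ccc(/C=C2/CN(C)/C(=N/c3ccc(OC)cc3)S2)cc1` gives 8700 nM, the lower of the two numbers so far, while compound 1 `COc1ccc(/C=C2/CN(C)/C(=N/c3ccc(C(C)(C)C)cc3)S2)cc1` gives 28700 nM there. Compound 3 `COc1ccc(/C=C2/CN(C)/C(=N/c3ccc(Br)cc3)S2)cc1` differs from compound 2 by bromo in place of methoxy on an aromatic carbon and nothing else. Within the data shown here, the one measured step at this place is a 3.3-fold lower number from compound 1 to compound 2 (0.52 log units; beyond the scatter) and it offers only thin guidance. A small move toward a higher number is therefore expected in this assay with the estimated change being a 1.5-fold higher number from compound 2 to compound 3 (0.17 log units; within the scatter) at the middle. Compound 3 is estimated at 13000 nM with an expected range of 5500 nM to 30000 nM overall.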

Compound 3, half-maximal inhibitory concentration: 7400 nM
Compound 3: the middle estimate sits 1.8-fold (0.24 log units) above what was measured, within the range that was stated.
By their numbers in this assay, from the lowest: compounds 3 and 2 (each within the scatter of the next); then compound 1.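

In this assay, the exchange at this place, para to a large group, gives a 1.2-fold lower number from compound 2 to compound 3 (0.07 log units; within the scatter) and so leaves bromo and methoxy indistinguishable here. Bromo in place of tert-butyl gives a 3.9-fold lower number from compound 1 to compound 3 (0.59 log units; beyond the scatter) and shows that the lower number is not particular to methoxy. Nothing measured here offers an explanation for this. From the compounds shown here alone, it remains open how an amine, a carboxylic acid or a longer chain would read at this place. Whether a hydroxy group or fluoro would match bromo and methoxy is also unsettled.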